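Ether-linked piperidine variant in a sulfonamide-acylated series

A few compounds are considered here, and "the series" means these few. Any claim that something is new, unique, unknown or untested is made for them only; others in the source may bear on it.

Measured so far:
- compound 1 `CC1(C)CCC(CN2CCN(c3ccc(C(=O)NS(=O)(=O)c4ccc(NCC5CCOCC5)c([N+](=O)[O-])c4)c(Oc4cnc5[nH]ccc5c4)c3)CC2)=C(c2cccc(C(F)(F)F)c2)C1`: 63 nM
- compound 2 `CN1CCC(CNc2ccc(S(=O)(=O)NC(=O)c3ccc(N4CCN(CC5=C(c6ccc(C(F)(F)F)cc6)CC(C)(C)CC5)CC4)cc3Oc3cnc4[nH]ccc4c3)cc2[N+](=O)[O-])C1`: 8.3 nM

Both numbers come from a functional assay on RS4-11 cells (Homo sapiens) for inhibition, read by CCK-8 assay, with a stated time of 72 h; a higher number here means a weaker inhibitor, a lower number a stronger inhibitor. Compound 2 holds the lowest number of the two; the nearest is compound 1, whose value is higher by a gap that lies beyond the scatter. Going by the values given here, compounds 1 and 2 differ in more than one place, so no single step between them can be separated out.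

Compound 3 `CCN1CCC(COc2ccc(S(=O)(=O)NC(=O)c3ccc(N4CCN(CC5=C(c6ccc(C(F)(F)F)cc6)CC(C)(C)CC5)CC4)cc3Oc3cnc4[nH]ccc4c3)cc2[N+](=O)[O-])CC1` has not been measured. Relative to compound 2 the change is (1-ethylpiperidin-4-yl)methoxy in place of ((1-methylpyrrolidin-3-yl)methyl)amino on an aromatic carbon. The shared core is otherwise untouched. Among the compounds with values here, no step between measured compounds isolates a change of this kind, so the expectation rests on the value of compound 2 alone.

The step from compound 2 to compound 3 is expected to be small and toward a higher number, likely near the edge of the scatter, giving a 2.4-fold higher number from compound 2 to compound 3 (0.38 log units; beyond the scatter). For compound 3 in this assay the estimate is 20 nM, with a range from 6 nM to 70 nM.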

Compound 3, half-maximal inhibitory concentration: 4.9 nM
Compound 3: middle estimate off by 4.1-fold (0.61 log units), on the high side; the whole stated range lies above it.
By their numbers in this assay, from the lowest: compounds 3 and 2 (each within the scatter of the next); then compound 1.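

In this assay, placing (1-ethylpiperidin-4-yl)methoxy instead of ((1-methylpyrrolidin-3-yl)methyl)amino on the aromatic carbon ortho to the nitro group gives a 1.7-fold lower number from compound 2 to compound 3 (0.23 log units; within the scatter) and so leaves the read-out unchanged within the scatter. This position therefore accepts a six-membered ring in place of a five-membered one, and an oxygen link in place of a nitrogen link, with no measurable cost in this cell assay. The hydrogen-bond donor of the amino link, absent from the entering group, is thus not required for a value of this size in this pair, and nothing available here accounts for the result.

Ring size, linking atom and the methyl or ethyl group on the ring nitrogen all change in this one step, so their separate contributions stay unresolved, and a compensating pair of effects cannot be excluded. Going by these compounds, how far the position stretches also remains open, for instance whether a morpholine, a carboxylic acid or a longer chain between the ring and the oxygen would hold the value in this assay or lose it.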